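The source may report more compounds than this note shows. Statements on the series, on what has been measured and on what is new or still open speak of the compounds shown alone.

Of the compounds shown here, three built on a shared core have so far been tested in an ADME assay on MDCK cells (Canis lupus familiaris) for cytotoxicity, read by microscopy, with a stated time of 48 h; a higher number here means that more compound is tolerated, a lower number that less compound is tolerated. Compound 1 `C[C@H]1[C@H](NCc2cncnc2)C[C@H]2C[C@@H]1C2(C)C` carries a pyrimidin-5-yl group on a saturated chain carbon bound to an amine nitrogen. In this assay compound 1 gives > 100000 nM, which is a limit of the assay rather than a number. Compound 1 thus sits at the limit of > 100000 nM in this assay, at which 1 of the 3 values shown sits, the most tolerated end of what has been seen. Compound 2 `C[C@H]1[C@H](NCc2sccc2-c2ccccc2)C[C@H]2C[C@@H]1C2(C)C` gives 12500 nM in this assay, and compound 3 `C[C@H]1[C@H](NCc2ccc(C(C)(C)C)s2)C[C@H]2C[C@@H]1C2(C)C` gives 780 nM, so both are tolerated only at smaller amounts than compound 1.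

Compound 4 `Cc1csc(CN[C@@H]2C[C@H]3C[C@@H]([C@H]2C)C3(C)C)n1` has not yet been measured. It differs from compound 1 by 4-methyl-1,3-thiazol-2-yl in place of pyrimidin-5-yl on a saturated chain carbon bound to an amine nitrogen. Going by the values given here, no two measured compounds differ in exactly one place, so there is no directly comparable step to lean on. The measured values do show that exchanging the aromatic group can move the result by a wide margin, and the ring entering compound 4 contains sulfur, like the rings of compounds 2 and 3. A downward step, toward less tolerance, is therefore expected in this assay, though a smaller one than those seen. Compound 4 is expected to give about 40000 nM, within a range from 10000 nM to 100000 nM. This corresponds to an expected step of an at least 2.5-fold lower number from compound 1 to compound 4 (0.39 log units; beyond the scatter).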

Compound 4, minimum cytotoxic concentration: > 100000 nM
Compound 4: no number, only a limit; the forecaster's own chance of this, stated with the estimate: 35%; at least 2.5-fold (0.39 log units) between middle value and limit.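

In this assay compound 4 gives > 100000 nM, which is a limit of the assay and not a number. Compound 1 and compound 4 both rest at a limit, so no step between them can be read: the limit of > 100000 nM in this assay, at which 2 of the 4 values shown sit.

The compounds shown leave open whether 4-methyl-1,3-thiazol-2-yl in place of pyrimidin-5-yl changes the result at all.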